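Methyl in Place of Hydrogen: Expected Cytotoxicity of Compound 4

A few compounds are considered here, and "the series" means these few. Any claim that something is new, unique, unknown or untested is made for them only; others in the source may bear on it.

compound 1, `CCCCC(c1cc2ccc(C)cc2[nH]c1=O)N(Cc1ccc(F)cc1)Cc1ccc(C(C)C)cc1`: > 33000 nM
compound 2, `CCc1ccc2[nH]c(=O)c(CN(Cc3ccc(F)cc3)Cc3cccc4ccccc34)cc2c1`: > 5000 nM
compound 3, `COc1ccc(CN(Cc2ccc(C(C)(C)C)cc2)Cc2cc3cc(C)ccc3[nH]c2=O)cc1`: > 10000 nM

Of the compounds shown here, three sharing one core have been tested in a toxicity assay on MDCK cells (Canis lupus familiaris) for cytotoxicity, read by crystal violet staining, with a stated time of 48 h (on this read-out lower numbers stand for higher toxicity in this test and higher numbers for lower toxicity in this test), and none returned a number. For compound 1 the reading of > 33000 nM is a limit of this assay, not a measured value, as noted in the limit of > 33000 nM in this assay, at which 1 of the 3 values shown sits. For compound 2 the reading of > 5000 nM is likewise a limit, see (the limit of > 5000 nM in this assay, at which 1 of the 3 values shown sits). For compound 3 the reading of > 10000 nM is again a limit, recorded in the limit of > 10000 nM in this assay, at which 1 of the 3 values shown sits. Compound 3 therefore stands among three limits of differing height, and no order among the three compounds can be drawn from them.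

Going by the values given here, no pair of measured compounds differs in only one place, so no measured step exists to lean on. Compound 4 `COc1ccc(C(C)N(Cc2ccc(C(C)(C)C)cc2)Cc2cc3cc(C)ccc3[nH]c2=O)cc1` differs from compound 3 by methyl in place of hydrogen on a saturated chain carbon bound to an amine nitrogen and an aromatic carbon. With only limits on hand, the expectation for this assay is a step no larger than the usual scatter, in no particular direction, so that compound 4 is most likely to return a limit as well. The estimated step that the limit leaves unreadable from compound 3 to compound 4 is accordingly close to nothing. Compound 4 is expected at about 20000 nM, within 7000 nM to 50000 nM.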

Compound 4, half-maximal cytotoxic concentration: > 5000 nM
Compound 4: a limit, no number; the forecaster's own chance of this, stated with the estimate: 80%; the middle value does not contradict the limit.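

Going by these compounds alone, compound 3 and compound 4 both returned limits rather than numbers in this assay, so no step from methyl in place of hydrogen can be read between them. The compounds shown leave open what cytotoxic concentration any of them actually has, and whether changing 4-methoxybenzyl to 1-(4-methoxyphenyl)ethyl alters it at all.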